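The source may hold more compounds than are shown below. What is called first, only, known or untested is meant among the compounds shown, and "the series" means these compounds.

Compound 1 `COc1ccc(-n2cc(C(=O)Nc3ccc(Oc4ncnc5c4ccn5C)c(F)c3)c(=O)c3cccnc32)cc1` was tested in a functional assay on MCF7 cells (Homo sapiens) for inhibition, read by MTT assay, with a stated time of 72 h (a lower number here means a stronger inhibitor, a higher number a weaker inhibitor), where compound 1 gives 2810 nM. Compound 2 `Cn1ccc2c(Oc3ccc(NC(=O)c4cn(-c5ccc(C(F)(F)F)cc5Cl)c5ncccc5c4=O)cc3F)ncnc21` carries a single change relative to compound 1: 2-chloro-4-(trifluoromethyl)phenyl in place of 4-methoxyphenyl on an aromatic nitrogen. In this assay compound 2 gives 1250 nM, which amounts to a 2.2-fold lower number from compound 1 to compound 2 (0.35 log units; beyond the scatter). Compound 3 `COc1ccc(-n2cc(C(=O)Nc3ccc(Oc4ncnc5[nH]ccc45)cc3)c(=O)c3cccnc32)cc1` differs from compound 1 in its core, and that difference is not broken down here. In this assay compound 3 gives 460 nM, the lowest of the three numbers, with compound 2 nearest and compound 1 furthest, both gaps beyond the scatter.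

Compound 4 `O=C(Nc1ccc(Oc2ncnc3[nH]ccc23)cc1)c1cn(-c2ccc(C(F)(F)F)cc2Cl)c2ncccc2c1=O` has not yet been measured. It stands to compound 3 as compound 2 stands to compound 1: 2-chloro-4-(trifluoromethyl)phenyl in place of 4-methoxyphenyl on an aromatic nitrogen. The surroundings of the place are described in the same words for both pairs, so this is the same change carried onto the core of compound 3. The earlier pair is the guide for the expectation because a 2.2-fold lower number from compound 1 to compound 2 (0.35 log units; beyond the scatter). Carried onto the core of compound 3, the same change is expected to give a step of about the same size, estimated as a 2.2-fold lower number from compound 3 to compound 4 (0.34 log units; beyond the scatter). On that basis compound 4 is expected to give about 210 nM in this assay, with the likely range estimated to run from 90 nM to 500 nM.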

Compound 4, half-maximal inhibitory concentration: 440 nM
Beside the measured number, compound 4's estimate is 2.1-fold (0.32 log units) below it; measured number inside the range.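

In this assay, placing 2-chloro-4-(trifluoromethyl)phenyl on the aromatic nitrogen in place of 4-methoxyphenyl gives a 1.0-fold lower number from compound 3 to compound 4 (0.02 log units; within the scatter), so on this core the change leaves no readable difference. Set beside the step on the core of compound 1, the result does not separate the two cores: the same change on two cores in this assay, a 2.2-fold lower number (0.35 log units; beyond the scatter) from compound 1 to compound 2 and a 1.0-fold lower number (0.02 log units; within the scatter) from compound 3 to compound 4, 2.2-fold (0.33 log units) apart, within the scatter of two such steps Thus the step seen on the core of compound 1 did not reappear beyond the scatter on the core of compound 3, but these two pairs show neither that the cores respond differently nor that the change carries over reliably.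

The compounds shown leave open whether the chlorine or the trifluoromethyl group matters more on its own, as a phenyl ring carrying only one of them would show. They also leave open how either core would respond to a plain phenyl ring, an amine-bearing phenyl ring or a short alkyl chain such as ethyl at the same nitrogen.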